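Benzyl group changes on a shared core

The source may report more compounds than this note shows. Statements on the series, on what has been measured and on what is new or still open speak of the compounds shown alone.

- compound 1 `COc1cc(OC)c(-c2coc3cc(OCc4ccc(Br)cc4)ccc3c2=O)cc1OC` gives 1000 nM in a functional assay on A-375 cells (Homo sapiens) for antiproliferative activity, read by MTT assay, with a stated time of 24 h; a higher number here means a weaker inhibitor, a lower number a stronger inhibitor
- compound 2 `COc1cc(OC)c(-c2coc3cc(OCc4ccccc4Cl)ccc3c2=O)cc1OC` gives 2020 nM in this assay

Compound 2 holds the higher of the two numbers and is the weaker of the pair. Among the compounds with values here, compound 3 `COc1cc(OC)c(-c2coc3cc(OCc4cccc(C(F)(F)F)c4)ccc3c2=O)cc1OC` carries 3-(trifluoromethyl)phenyl in place of 2-chlorophenyl on a saturated chain carbon bound to an oxygen on an aromatic ring and this group has no measured precedent. Within the data shown here, the only step bearing on it is the modest 2.0-fold higher number from compound 1 to compound 2 (0.31 log units; beyond the scatter) at the same place. On that size alone, a similarly modest step is expected in this assay and only tentatively towards a lower number. The estimate is a 1.3-fold lower number from compound 2 to compound 3 (0.13 log units; within the scatter) for this change. Compound 3 is estimated at 1500 nM with an expected range of 600 nM to 3800 nM in this series.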

Compound 3, half-maximal inhibitory concentration: 1140 nM
Compound 3: middle estimate off by 1.3-fold (0.12 log units), on the high side; the measured number falls inside the stated range.
By their numbers in this assay, from the lowest: compounds 1, 3 and 2 (each within the scatter of the next, the first and the last beyond it).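

In this assay, 3-(trifluoromethyl)phenyl on a saturated chain carbon bound to an oxygen on an aromatic ring cannot be separated from either earlier group (a 1.8-fold lower number from compound 2 to compound 3 (0.25 log units; within the scatter); a 1.1-fold higher number from compound 1 to compound 3 (0.06 log units; within the scatter)). Compound 3 therefore overlaps both compound 1 and compound 2, even though those two lie beyond the scatter of each other, so this place accepts all three substituted benzyl groups without a clear break. No measurement is available to explain this result.

Still open, on these data alone, is whether an amine or a carboxylic acid on the benzyl ring would shift the number beyond this band, and a longer chain in place of the benzyl group is equally untested here.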